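Enlarging the Ester Group of Compound 2

The source may hold more compounds than are shown below. What is called first, only, known or untested is meant among the compounds shown, and "the series" means these compounds.

Compound 1 `CCN1C(=O)C(=O)c2cc(/C=C/C(=O)OC)ccc21` gives 200 nM in a functional assay on Jurkat cells (Homo sapiens) for antiproliferative activity, read by MTT assay, with a stated time of 48 h (on this read-out higher numbers stand for weaker inhibition and lower numbers for stronger inhibition), and compound 2 `COC(=O)/C=C/c1ccc2c(c1)C(=O)C(=O)N2Cc1ccc(OC)cc1` gives 30 nM, the lowest of the two numbers. Among the measured compounds shown here, the one measured step, a 6.7-fold lower number from compound 1 to compound 2 (0.82 log units; beyond the scatter), concerned a different place in the molecule. Compound 3 `COc1ccc(CN2C(=O)C(=O)c3cc(/C=C/C(=O)OC(C)(C)C)ccc32)cc1` differs from compound 2 in that (tert-butyl in place of methyl on an oxygen next to a carbonyl group). For the measured compounds named here, no measured step touches that oxygen, so the data give no direction, and a step within the scatter is expected, a 1.3-fold higher number from compound 2 to compound 3 (0.12 log units; within the scatter). Compound 3 is therefore estimated at 40 nM, with a range from 10 nM to 160 nM.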

Compound 3, half-maximal inhibitory concentration: 310 nM
Compound 3: the middle estimate sits 7.8-fold (0.89 log units) below what was measured, and the stated range ends below it.
By their numbers in this assay, from the lowest: compound 2; then compounds 1 and 3 (each within the scatter of the next).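

The oxygen of the ester is a place where a change registers: in this assay, tert-butyl in place of methyl gives a 10-fold higher number from compound 2 to compound 3 (1.01 log units; beyond the scatter) and so weaker inhibition. Going from methyl to tert-butyl on this oxygen therefore does not leave the read-out untouched, as the earlier compounds could not show. Nothing available here accounts for this step. As far as these compounds go, two groups on one oxygen give no trend, so it stays open how an ethyl group, a benzyl group or a free carboxylic acid would read at this place.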